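Moving the Hydroxyl Around Its Phenyl Ring

The source may report more compounds than this note shows. Statements on the series, on what has been measured and on what is new or still open speak of the compounds shown alone.

Compound 1 `Oc1cccc(-c2cc(-c3ccc(Cl)cc3)nc(-c3ccccn3)c2)c1` stands highest of the three compounds measured in an assay on isolated protein for inhibition of DNA topoisomerase 1 (Homo sapiens), with a stated time of 30 min, tested at 100 uM; on this read-out higher numbers stand for a stronger effect at the one concentration tested and lower numbers for a weaker effect: compound 1 gives 30%. Compound 2 `Oc1cccc(-c2cc(-c3cccc(Cl)c3)nc(-c3ccccn3)c2)c1` gives 0.4%, and compound 3 `Oc1cccc(-c2cc(-c3ccc(Cl)cc3)nc(-c3ccsc3)c2)c1` gives 11.7%. Both measured changes to compound 1 lowered the read-out: a number 29.6 percentage points lower from compound 1 to compound 2 (beyond the scatter), and a number 18.3 percentage points lower from compound 1 to compound 3 (beyond the scatter). Compound 4 `Oc1ccc(-c2cc(-c3ccc(Cl)cc3)nc(-c3ccccn3)c2)cc1` differs from compound 1 in a third way: 4-hydroxyphenyl in place of 3-hydroxyphenyl on an aromatic carbon. Within the data shown here, neither measured step touches the hydroxyphenyl group, so neither bears directly on this change; they show only that the read-out of compound 1 has fallen, by a modest amount, each time one of its rings was altered. Among the measured compounds shown here, with that as the sole guide, a decrease for compound 4 is expected, of a size that may or may not exceed the usual scatter, and the expected step is a number 15 percentage points lower from compound 1 to compound 4 (beyond the scatter). Compound 4 is therefore estimated to give 15%, within a range from 0% to 35%.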

Compound 4, a percentage reported as inhibition, at one concentration (the size of the read-out at that concentration, not a potency): 12.7%
The estimate for compound 4 lay 2.3 percentage points above the measured number, within the range that was stated.
By their numbers in this assay, from the lowest: compound 2; then compounds 3 and 4 (each within the scatter of the next); then compound 1.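

In this assay, moving the hydroxyl from the 3-hydroxyphenyl to the 4-hydroxyphenyl arrangement gives a number 17.3 percentage points lower from compound 1 to compound 4 (beyond the scatter) and so shows that the read-out also responds to a change on this ring, which neither earlier step touched. The two groups have the same atoms and the same counts of hydrogen-bond donors and acceptors, so the only difference between the two compounds is where the hydroxyl sits on the ring, and that alone moves the number by more than the scatter. Nothing measured here explains why this placement matters.

The compounds shown leave open whether the hydroxyl is needed at all, since each of them carries one. A methoxy group or an amine in its place, or a plain phenyl ring without it, would address that question.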